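A few compounds are considered here, and "the series" means these few. Any claim that something is new, unique, unknown or untested is made for them only; others in the source may bear on it.

Measured compounds:
- compound 2, `C#Cc1cccc(Nc2ncnc3ccc(NC(=S)Nc4ccc(S(N)(=O)=O)cc4)cc23)c1`: 15300 nM
- compound 1, `C#Cc1cccc(Nc2ncnc3cc(OC)c(OCCCCC(=O)Nc4ccc(S(N)(=O)=O)cc4)cc23)c1`: 17700 nM

In a functional assay on A-431 cells (Homo sapiens) for antiproliferative activity, read by MTT assay, with a stated time of 72 h (on this read-out higher numbers stand for weaker inhibition and lower numbers for stronger inhibition), compound 2 gives 15300 nM. In the same assay compound 1 gives 17700 nM. Of the two numbers that of compound 2 is the smaller, but the gap to compound 1 lies within the usual scatter of repeated measurements, so the two compounds cannot be told apart on these data. Both numbers sit in the weak range of this assay.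

Compound 3, `NS(=O)(=O)c1ccc(NC(=S)Nc2ccc3ncnc(Nc4cccc(Cl)c4)c3c2)cc1`, has not yet been measured. It differs from compound 2 in one place: chloro in place of ethynyl on an aromatic carbon. The rest of the molecule, including the thiourea-linked sulfonamide part, is unchanged. Among the measured compounds shown here, no pair of measured compounds carries this change, so there is no step on record for it. Both measured compounds are weak, and a single exchange on the outer aromatic ring gives no reason on these data to expect a move beyond the scatter in either direction. The step of a 1.2-fold higher number from compound 2 to compound 3 (0.07 log units; within the scatter) is estimated to stay within the scatter. Compound 3 is therefore expected to give about 18000 nM, with a range from 6000 nM to 55000 nM.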

Compound 3, half-maximal inhibitory concentration: 15000 nM
Beside the measured number, compound 3's estimate is 1.2-fold (0.08 log units) above it, and the stated range covers the measured number.
By their numbers in this assay, from the lowest: compounds 3, 2 and 1 (each within the scatter of the next).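

In this assay the series now has its first step at a single place: going from 3-ethynylphenyl to 3-chlorophenyl gives a 1.0-fold lower number from compound 2 to compound 3 (0.01 log units; within the scatter) while the thiourea-linked sulfonamide part stays fixed. At this aromatic carbon, a chloro group and an ethynyl group therefore cannot be told apart on this read-out, even though the exchange removes the triple bond and replaces two carbon atoms with one chlorine atom. Compound 2 and compound 3 both remain in the weak range of the assay, so this exchange does not separate them, and no measurement at hand bears on why the two groups read alike.

Going by these compounds, it remains open whether a different group on the same aromatic carbon, such as an amine, a carboxylic acid or a longer chain, would give a step beyond the scatter. On these data alone, it also remains open whether the same chloro for ethynyl exchange would read alike on compound 1, with its amide-linked sulfonamide chain, since this single step rests on the thiourea-linked compounds alone.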